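From 2-Phenylethenyl to Thiophen-3-yl Under Three Limits

The source may report more compounds than this note shows. Statements on the series, on what has been measured and on what is new or still open speak of the compounds shown alone.

Compound 1 `CCCCN1CCC(C(=O)Nc2cc(Cl)c(N)cc2OC)CC1`: > 10 mg/kg
Compound 2 `COc1cc(N)c(Cl)cc1NC(=O)C1CCN(CC2CCCC2)CC1`: > 10 mg/kg
Compound 3 `COc1cc(N)c(Cl)cc1NC(=O)C1CCN(C/C=C/c2ccccc2)CC1`: > 10 mg/kg

In a functional assay on the whole organism for antagonist activity, with Mus musculus as the target (a lower number here means that less compound is needed, a higher number that more compound is needed for the effect), compound 1 reaches only a limit of the assay, not a number. Compound 2 likewise gives only a limit. Compound 3 also stands at a limit, so its place among the numbers shown cannot be read; (the limit of > 10 mg/kg in this assay, at which 3 of the 3 values shown sit). The steps a step that the two limits leave unreadable from compound 1 to compound 3 and a step that the two limits leave unreadable from compound 2 to compound 3 concern the same place as the change to compound 4 `COc1cc(N)c(Cl)cc1NC(=O)C1CCN(Cc2ccsc2)CC1`, namely (thiophen-3-yl in place of 2-phenylethenyl on a saturated chain carbon bound to an amine nitrogen in a ring). Neither step has a readable size, and a step that the two limits leave unreadable from compound 1 to compound 2 is no better. No step beyond the scatter can therefore be expected in either direction, and a further limit is the likeliest outcome. Compound 4 is estimated at 15 mg/kg, with a range from 4 mg/kg to 60 mg/kg. The expected step is a step that the limit leaves unreadable from compound 3 to compound 4.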

Compound 4, dose for half-maximal effect: 3.4 mg/kg
For compound 4 the middle estimate is 4.4-fold (0.64 log units) above the measured one; measured number outside the range, below it.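

In this assay this position on a saturated chain carbon bound to an amine nitrogen in a ring gives its first readable result: thiophen-3-yl brings an at least 2.9-fold lower number from compound 3 to compound 4 (0.46 log units; beyond the scatter), along with an at least 2.9-fold lower number from compound 2 to compound 4 (0.46 log units; beyond the scatter) and an at least 2.9-fold lower number from compound 1 to compound 4 (0.46 log units; beyond the scatter). Each size is only a minimum, and the other compounds remain at a limit of the assay: the limit of > 10 mg/kg in this assay, at which 3 of the 4 values shown sit. The steps among compound 1, compound 2 and compound 3 still cannot be read.

The compounds shown leave open whether the gain belongs to the sulfur or to the smaller ring, as furan-3-yl or phenyl at this place could tell. From the compounds shown here alone, how a thiophen-3-yl carrying a carboxylic acid or an amine would fare also remains open.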